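The source may report more compounds than this note shows. Statements on the series, on what has been measured and on what is new or still open speak of the compounds shown alone.

Series notes. Compound 1 `CC1CCN(c2c(S(=O)(=O)c3ccccc3)cnc3ccc(F)cc23)CC1`, compound 2 `Cc1ccc(S(=O)(=O)c2cnc3ccc(F)cc3c2N2CCC(C)CC2)cc1F` and compound 3 `CC1CCN(c2c(S(=O)(=O)c3cccc(C#N)c3)cnc3ccc(F)cc23)CC1` share one core and differ only in the aryl group on a sulfonyl sulfur. In an assay on isolated protein for displacement of a labelled ligand from metabotropic glutamate receptor 5 (Homo sapiens), with a stated time of 60 min, tested at 1 uM (a lower number here means less inhibition, a higher number more inhibition at the concentration tested (going by the name of the read-out)), compound 1 gives 40%, compound 2 gives 86% and compound 3 gives 93%. Compound 3 stands highest of the three numbers, but only its gap to compound 1 is beyond the scatter: the step of a number 53 percentage points higher from compound 1 to compound 3 (beyond the scatter) is large, as is a number 46 percentage points higher from compound 1 to compound 2 (beyond the scatter), whereas a number 7 percentage points higher from compound 2 to compound 3 (within the scatter) is within the scatter, so compound 2 and compound 3 cannot be ordered.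

Compound 4 `COc1ccc(S(=O)(=O)c2cnc3ccc(F)cc3c2N2CCC(C)CC2)cc1Cl` is not yet measured. 3-chloro-4-methoxyphenyl in place of 3-cyanophenyl on a sulfonyl sulfur Both the 3-fluoro-4-methylphenyl of compound 2 and the 3-cyanophenyl of compound 3 sit far above the phenyl of compound 1 in this assay, and the only move between two substituted rings, a number 7 percentage points higher from compound 2 to compound 3 (within the scatter), stayed within the scatter. Within the data shown here, no measured step covers 3-chloro-4-methoxyphenyl itself, so the expectation rests on those two steps alone. The step expected in this assay is a number 8 percentage points lower from compound 3 to compound 4 (within the scatter), not beyond the scatter in either direction. Compound 4 is therefore estimated to give 85%, with a range from 65% to 96%.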

Compound 4, a percentage reported as inhibition, at one concentration (the size of the read-out at that concentration, not a potency): 82%
Estimate against measurement, compound 4: 3 percentage points above; the range from low to high includes it.
By their numbers in this assay, from the lowest: compound 1; then compounds 4, 2 and 3 (each within the scatter of the next, the first and the last beyond it).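

In this assay a third substituted ring on a sulfonyl sulfur, 3-chloro-4-methoxyphenyl, also stands well clear of the unsubstituted phenyl, with a number 42 percentage points higher from compound 1 to compound 4 (beyond the scatter) in this comparison, so all three substituted rings shown (compounds 2, 3 and 4) share this gain over phenyl and none goes against it. The substituted rings are not fully interchangeable, since a number 11 percentage points lower from compound 3 to compound 4 (beyond the scatter) gives the first modest separation between two of them, while a number 4 percentage points lower from compound 2 to compound 4 (within the scatter) leaves those two compounds unordered, so the exchange of 3-fluoro-4-methylphenyl for 3-chloro-4-methoxyphenyl has no readable effect here. Nothing available explains either the gain over phenyl or the modest separation among the substituted rings.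

The compounds shown leave open whether an aryl ring carrying an amine or a carboxylic acid, or a cyclohexyl group in place of the aryl group on the sulfonyl sulfur, would keep inhibition at this level. They also leave open how compounds 2, 3 and 4 compare at other concentrations, as each has a percentage at a single concentration only, and whether any change elsewhere on the shared core would make the number in this assay higher, lower or leave it level.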